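Chloro to cyclopropyl in compound 3: working notes

A few compounds are considered here, and "the series" means these few. Any claim that something is new, unique, unknown or untested is made for them only; others in the source may bear on it.

compound 1 `CC(=O)Nc1nc2ccc(-c3cnc(Cl)c(NS(=O)(=O)c4ccc(C)cc4)c3)cn2n1` gives 3760 nM
compound 2 `COc1ncc(-c2ccc3nc(NC(C)=O)nn3c2)cc1NS(=O)(=O)c1ccc(Cl)cc1` gives 2090 nM

Both values come from a functional assay on U-87MG ATCC cells (Homo sapiens) for antiproliferative activity, read by MTT assay, with a stated time of 48 h (on this read-out lower numbers stand for stronger inhibition and higher numbers for weaker inhibition), and nothing else has been measured so far. Compound 2 at 2090 nM stands within the usual scatter of compound 1 (3760 nM) and the two cannot be ranked.

Compound 3 `COc1ncc(-c2ccc3nc(NC(C)=O)nn3c2)cc1NS(=O)(=O)c1ccc(C2CC2)cc1` is still unmeasured. Set against compound 2, it carries cyclopropyl in place of chloro on an aromatic carbon of a six-membered aromatic ring of carbon only, para to a large group (cyclopropyl in place of chloro on an aromatic carbon). The same difference reads 4-chlorophenyl to 4-cyclopropylphenyl.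

Among the measured compounds shown here, no two measured compounds differ in one place only, so the series offers no direct guide to this change. In this assay no step beyond the scatter is expected in either direction, though that expectation rests on very little. The estimated change is a 1.0-fold lower number from compound 2 to compound 3 (0.02 log units; within the scatter) and it is expected to stay within the scatter. For compound 3 the estimated value is 2000 nM with an expected range from 700 nM to 5500 nM at this stage.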

Compound 3, half-maximal inhibitory concentration: 3730 nM
Compound 3: middle estimate off by 1.9-fold (0.27 log units), on the low side; the range from low to high includes it.
By their numbers in this assay, from the lowest: compounds 2, 3 and 1 (each within the scatter of the next).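

In this assay, among the compounds shown here, the change of chloro to cyclopropyl gives the first single-place comparison: a 1.8-fold higher number from compound 2 to compound 3 (0.25 log units; within the scatter). On this aromatic carbon, para to a large group, a three-membered non-aromatic ring of carbon can therefore stand where a single chlorine stood without a step beyond the scatter, at least on the core of compound 2 and in this one pair. No accompanying measurement speaks to what lies behind this result, so the finding stays a plain observation on the antiproliferative read-out.

On these data alone, one pair cannot show how far this position stays this flat, and it remains open whether an amine, a carboxylic acid or a longer chain such as n-butyl in the same place would give a step beyond the scatter. Compound 1 differs from compound 2 and from compound 3 in more than one place, so the separate contributions of methoxy, methyl and the chloro on the other ring also remain unresolved in this set.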